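Rearranged Cyanoguanidine Tail on a Shared Pyridazinone-Bearing Core

A few compounds are considered here, and "the series" means these few. Any claim that something is new, unique, unknown or untested is made for them only; others in the source may bear on it.

Compound 2 `CC/N=C(/NC#N)NCCCCCCn1nc(-c2ccccc2)ccc1=O` carries a cyanoguanidine group at the end of a chain on the shared core. In a functional assay on the whole organism with Rattus norvegicus as the target (on this read-out higher numbers stand for an effect only at larger amounts of compound and lower numbers for an effect already at smaller amounts), compound 2 gives only a limit, > 100 mg/kg, and not a number. Compound 1 `C/N=C(/NC#N)NCCCCCCn1nc(-c2ccccc2)ccc1=O` differs from it by a methyl in place of hydrogen on a saturated chain carbon bound to a double-bonded nitrogen. In this assay compound 1 likewise gives only a limit, > 100 mg/kg. The step from compound 1 to compound 2 is thus a step that the two limits leave unreadable from compound 1 to compound 2. For the measured compounds named here, compound 3 `CC/N=C(\S)NCCCn1nc(-c2ccccc2)ccc1=O` differs from compound 2 in more than one place, so no single step links the two. In this assay compound 3 gives 88.2 mg/kg. The prevailing reading among the measured compounds is the limit of > 100 mg/kg in this assay, at which 2 of the 3 values shown sit.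

Compound 4 `CN(C)/C(=N/CCCCCCn1nc(-c2ccccc2)ccc1=O)NC#N` differs from compound 2 by a group of 8 heavy atoms (4 carbon, 4 nitrogen; no ring) in place of a group of 8 heavy atoms (4 carbon, 4 nitrogen; no ring), on a saturated chain carbon, six bonds along the chain from an aromatic nitrogen. Going by the values given here, the only measured step, from compound 1 to compound 2, cannot be read, so it offers no size to carry over to this change. Compound 4 is therefore expected to sit near its measured neighbours, and the expected step is a step that the limit leaves unreadable from compound 2 to compound 4. Compound 4 is estimated at 130 mg/kg, with a range from 60 mg/kg to 300 mg/kg.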

Compound 4, dose for half-maximal effect: 92.5 mg/kg
Estimate against measurement, compound 4: 1.4-fold (0.15 log units) above; measured number inside the range.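

In this assay compound 4 gives a true number, 92.5 mg/kg, which shows that a readable value is possible with the rearranged group on a saturated chain carbon, six bonds along the chain from an aromatic nitrogen, where the same atoms are joined differently and the group has 1 hydrogen-bond donor in place of 2. Measured against its two neighbours, the change amounts to an at least 1.0-fold lower number from compound 2 to compound 4 (0.03 log units; that floor lies within the scatter), and to an at least 1.0-fold lower number from compound 1 to compound 4 (0.03 log units; that floor lies within the scatter). Each step is only a floor, so a real difference cannot yet be claimed, although a larger one is not ruled out.

As far as these compounds go, how far compound 1 and compound 2 truly lie from compound 4 stays unknown, since the comparison still rests on a limit: the limit of > 100 mg/kg in this assay, at which 2 of the 4 values shown sit. From the compounds shown here alone, it also remains open whether a longer chain would change the number for the rearranged group, and whether an amine or a carboxylic acid in its place would give a readable value in this whole-animal test.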